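The compounds below may be only part of what the source reports. "The series", "measured", "known", "first", "only" and "open" are said of these compounds alone.

In an ADME assay on HEK293 cells (Homo sapiens) for antiproliferative activity, read by MTT assay, with a stated time of 24 h (on this read-out lower numbers stand for stronger inhibition and higher numbers for weaker inhibition), compound 1 `COc1cc(C(=O)/C=C/c2cc(-c3cc(OC)c(OC)c(OC)c3)n3nc(-c4ccccc4)cc3n2)cc(OC)c1OC` gives >= 100000 nM, which is a limit of the assay and not a number. Compound 2 `COc1ccc(-c2cc(/C=C/C(=O)c3cc(OC)c(OC)c(OC)c3)nc3cc(-c4ccccc4)nn23)cc1OC` gives 35000 nM. Compound 3 `COc1cc(-c2cc(/C=C/C(=O)c3ccc(C)cc3)nc3cc(-c4ccccc4)nn23)cc(OC)c1OC` departs from compound 1 elsewhere: 4-methylphenyl in place of 3,4,5-trimethoxyphenyl on a carbonyl carbon, with 4-methylphenyl in place of 3,4,5-trimethoxyphenyl on a carbonyl carbon. Among the measured compounds shown here, the only measured step that bears on this is an at least 2.8-fold lower number from compound 1 to compound 2 (0.45 log units; beyond the scatter), where hydrogen replaces methoxy on an aromatic carbon. It is an indirect guide, so a modest move to a lower number in this assay is expected. The expected step is an at least 2.0-fold lower number from compound 1 to compound 3 (0.30 log units; that floor lies within the scatter). Compound 3 is estimated at 50000 nM, with an expected range of 15000 nM to 100000 nM.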

Compound 3, half-maximal inhibitory concentration: 50400 nM
Beside the measured number, compound 3's estimate is 1.0-fold (0.00 log units) below it; the range from low to high includes it.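

On a carbonyl carbon, the shared core tolerates the exchange of 3,4,5-trimethoxyphenyl for 4-methylphenyl, which the earlier methoxy-to-hydrogen step elsewhere in the molecule could not show: in this assay, this exchange gives an at least 1.9-fold lower number from compound 1 to compound 3 (0.29 log units; that floor lies within the scatter). Compound 3 thus has a measured number with no oxygen in this group. The value of compound 1, >= 100000 nM, is a limit and not a number, so the true size of this step stays unknown: the limit of >= 100000 nM in this assay, at which 1 of the 3 values shown sits.

The compounds shown leave open how a plain phenyl, a 4-chlorophenyl or a phenyl bearing an amine would read on this carbonyl carbon.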